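The source may report more compounds than this note shows. Statements on the series, on what has been measured and on what is new or still open speak of the compounds shown alone.

Compound 1, `CCN(CC)S(=O)(=O)c1ccc(S(=O)(=O)N2CCC[C@@H](C(=O)N(C)C(C)C)C2)cc1`, carries the shared core with an isopropyl(methyl)carbamoyl group on the piperidine. In a functional assay on MIA PaCa-2 cells (Homo sapiens) for inhibition, read by MTT assay, with a stated time of 7 days (on this read-out higher numbers stand for weaker inhibition and lower numbers for stronger inhibition), compound 1 gives 6200 nM, the highest of the two numbers recorded so far. Compound 2, `CCN(CC)S(=O)(=O)c1ccc(S(=O)(=O)N2CCC[C@@H](C(=O)N3CCN(c4nc(C(F)(F)F)no4)CC3)C2)cc1`, replaces that amide with a piperazine bearing a trifluoromethyl-oxadiazole; in this assay compound 2 gives 600 nM, a gap from compound 1 that lies beyond the usual scatter. These two values alone show that the amide end of the molecule matters for the read-out, and that the larger, heterocycle-bearing substituent goes with the stronger inhibition.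

Compound 3, `CCN(CC)S(=O)(=O)c1ccc(S(=O)(=O)N2CCC[C@@H](C(=O)NC)C2)cc1`, has not been measured in this assay. It differs from compound 1 in one place: hydrogen in place of isopropyl on an amide-type nitrogen. Among the compounds with values here, no step between measured compounds covers this change, so the expectation can rest only on the two values above. Since the step from compound 1 to compound 2 pairs a bulkier amide with the lower number, a trimming to methylcarbamoyl is expected to move the number, if at all, the other way, by a 1.6-fold higher number from compound 1 to compound 3 (0.21 log units; within the scatter). For compound 3 the estimate in this assay is 10000 nM, with a range from 3000 nM to 35000 nM.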

Compound 3, half-maximal inhibitory concentration: 8600 nM
Beside the measured number, compound 3's estimate is 1.2-fold (0.07 log units) above it; the range from low to high includes it.
By their numbers in this assay, from the lowest: compound 2; then compounds 1 and 3 (each within the scatter of the next).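

In this assay, putting hydrogen in place of isopropyl on the amide-type nitrogen gives a 1.4-fold higher number from compound 1 to compound 3 (0.14 log units; within the scatter), so this single exchange does not separate compound 3 from compound 1 on this read-out. The earlier compounds shown here showed only that the amide end as a whole can matter; this pair shows that, with the rest of compound 1 held fixed, the isopropyl can be absent without a change that stands out from the scatter. Nothing available here speaks to the reason for this result.

The compounds shown leave open how the read-out responds when this nitrogen carries something other than hydrogen or isopropyl, such as a longer chain like n-butyl, a chain ending in an amine, or a chain ending in a carboxylic acid. They also leave open whether the remaining methyl on the same nitrogen can be exchanged in the same way, for instance for hydrogen or an ethyl group, and what that would do to the number.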